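The source may hold more compounds than are shown below. What is called first, only, known or untested is meant among the compounds shown, and "the series" means these compounds.

Measured so far in a physicochemical assay for lipophilicity, measured as octanol-water partition, at pH 7.4; on this read-out higher numbers stand for higher lipophilicity and lower numbers for lower lipophilicity:
Compound 1 `O=C([C@H](O)CS(=O)(=O)c1ccc2cc(Cl)ccc2c1)N1CCC(n2cc[nH]c2=O)CC1`: 1.79
Compound 2 `O=C([C@H](O)CS(=O)(=O)c1ccc2cc(Cl)ccc2c1)N1CCC(N2CCOC2=O)CC1`: 1.75
Compound 3 `O=C([C@H](O)CS(=O)(=O)c1ccc2cc(Cl)ccc2c1)N1CCC(N2CCCC2)CC1`: 1.56

Compound 3 stands within the scatter of both other compounds, and no order can be read among the three values. Compound 4 `O=C([C@H](O)CS(=O)(=O)c1ccc2cc(Cl)ccc2c1)N1CCC(N2CCOCC2=O)CC1` follows from compound 3 by 3-oxomorpholin-4-yl in place of pyrrolidin-1-yl on a saturated ring carbon, in words 3-oxomorpholin-4-yl in place of pyrrolidin-1-yl on a saturated ring carbon.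

Within the data shown here, no measured step makes this exact exchange. The closest is a number 0.19 log units lower from compound 2 to compound 3 (within the scatter), which has pyrrolidin-1-yl entering in place of 2-oxo-1,3-oxazolidin-3-yl. Also relevant are a number 0.23 log units lower from compound 1 to compound 3 (within the scatter) and a number 0.04 log units lower from compound 1 to compound 2 (within the scatter). All three steps are small, although the groups exchanged differ considerably, so no step beyond the scatter is expected in this assay. The estimated step is a number 0.12 log units higher from compound 3 to compound 4 (within the scatter). For compound 4 the expected value is 1.68, with an estimated range of 1.38 to 1.98.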

Compound 4, distribution coefficient: 1.85
For compound 4 the middle estimate is 0.17 log units below the measured one; measured number inside the range.
By their numbers in this assay, from the lowest: compounds 3, 2, 1 and 4 (each within the scatter of the next).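

In this assay, the six-membered 3-oxomorpholin-4-yl on this saturated ring carbon stays within the scatter of all three five-membered groups: a number 0.29 log units higher from compound 3 to compound 4 (within the scatter), a number 0.10 log units higher from compound 2 to compound 4 (within the scatter) and a number 0.06 log units higher from compound 1 to compound 4 (within the scatter). Across these four compounds, neither the change of ring size nor the exchanges among the groups at this position separates the values beyond the scatter, so no order can be read from them. No supporting measurement bears on why the four values lie so close.

From the compounds shown here alone, it remains open whether a carboxylic acid or a longer alkyl chain on the same ring carbon would give a step beyond the scatter. The compounds shown also leave open whether this lack of separation holds when the rest of the shared core is changed.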